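The source may hold more compounds than are shown below. What is called first, only, known or untested is meant among the compounds shown, and "the series" means these compounds.

In a functional assay on SEM cells (Homo sapiens) for cytotoxicity, with a stated time of 72 h (on this read-out lower numbers stand for an effect already at smaller amounts and higher numbers for an effect only at larger amounts of compound), compound 3 `COc1ccc(/C=C/[C@@](C)(/C=C/c2ccc(O)cc2)CCC=C(C)C)cc1` gives only a limit, > 36600 nM. Compound 1 `CCOC(=O)/C(C)=C/c1cc(/C=C/[C@](C)(/C=C/c2ccc(OC)cc2)CCC=C(C)C)ccc1O` also gives only a limit, > 36600 nM. Compound 2 `COc1ccc(/C=C/[C@@](C)(/C=C/c2ccc(O)c(/C=C/C(=O)OC(C)(C)C)c2)CCC=C(C)C)cc1` likewise gives only a limit, > 36600 nM. Together these results make up (the limit of > 36600 nM in this assay, at which 3 of the 3 values shown sit). Compound 4 `CC(C)=CCC[C@@](C)(/C=C/c1ccccc1)/C=C/c1ccc(O)cc1` has hydrogen in place of methoxy on an aromatic carbon, para to a large group: hydrogen in place of methoxy on an aromatic carbon. Among the compounds with values here, the steps that bear on it only indirectly are a step that the two limits leave unreadable from compound 1 to compound 3 and a step that the two limits leave unreadable from compound 2 to compound 3. Both concern a different group, so neither gives a size to carry over. The expectation therefore rests on compound 3, whose limit is > 36600 nM. The expected change, a step that the limit leaves unreadable from compound 3 to compound 4, is none beyond the scatter in this assay, with no direction favoured. Compound 4 is estimated at 40000 nM, within an expected range of 15000 nM to 80000 nM.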

Compound 4, half-maximal effective concentration: > 36600 nM
Compound 4: only a limit was reported; the forecaster's own chance of this, stated with the estimate: 80%; the middle value does not contradict the limit.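

Within the data shown here, compound 3 and compound 4 both give only limits in this assay, so no step between them can be read. The compounds shown leave open how large any effect of these changes to the shared core is: the limit of > 36600 nM in this assay, at which 4 of the 4 values shown sit.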